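The source may hold more compounds than are shown below. What is called first, only, known or untested is meant among the compounds shown, and "the series" means these compounds.

Measured so far in an ADME assay on microsomes from liver (Rattus norvegicus) for metabolic stability, read by LC-MS, using NADPH, with a stated time of 30 min, tested at 0.1 uM, in the presence of a further agent that is not named here; on this read-out lower numbers stand for a less stable compound and higher numbers for a more stable compound:
compound 1 `Nc1ncc(-c2ccc(C(=O)O)cc2)nc1-c1ccc(C(F)(F)F)cc1` — > 90%, a limit of the assay
compound 2 `Nc1ncc(-c2ccc(C(=O)N3CCC(O)C3)cc2)nc1-c1ccc(C(F)(F)F)cc1` — > 90%, a limit of the assay

In this assay compound 1 gives > 90%, which is a limit and not a number. Compound 2 in this assay gives > 90%, again a limit. The step that the two limits leave unreadable from compound 1 to compound 2 therefore cannot be sized, because both values sit at the limit of > 90% in this assay, at which 2 of the 2 values shown sit. Compound 2 thus stands at the upper limit of what this assay reports, level with compound 1 as far as the numbers show.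

Compound 3 `Nc1ncc(-c2ccc(C(=O)N3CC(O)C3)cc2)nc1-c1ccc(C(F)(F)F)cc1` is not yet measured in this assay. Its difference from compound 2 is 3-hydroxyazetidin-1-yl in place of 3-hydroxypyrrolidin-1-yl on a carbonyl carbon. Going by the values given here, the only measured step, that from compound 1 to compound 2, is the one at the same carbonyl carbon, and its size is not readable; nothing measured here speaks for a shift in either direction. The expectation is therefore no step beyond the scatter, a step that the limit leaves unreadable from compound 2 to compound 3, with compound 3 most likely reported again at the limit. Compound 3 is estimated at 92% in this assay, within 80% to 99%.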

Compound 3, percent of the compound remaining in the Rattus norvegicus assay: > 90%
Compound 3 gave a limit, no number; the forecaster's own chance of this, stated with the estimate: 70%; the middle value lies beyond the limit too.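

In the Rattus norvegicus assay no step can be read among compound 1, compound 2 and compound 3, because all three values are the same limit of the assay: the limit of > 90% in the Rattus norvegicus assay, at which 3 of the 3 values shown sit.

In a physicochemical assay for solubility, read by HPLC, using the shake flask method, in phosphate buffer, with a stated time of 2 h, at pH 6.5 (a higher number here means a more soluble compound, a lower number a less soluble compound), compound 2 gives 77000 nM and compound 3 gives 55000 nM, which is a 1.4-fold lower number from compound 2 to compound 3 (0.15 log units; within the scatter).

The compounds shown leave open whether any change on the carbonyl carbon shifts the read-out in the Rattus norvegicus assay.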